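A Chlorine Enters the Six-Membered Ring of Compound 3

The compounds below may be only part of what the source reports. "The series", "measured", "known", "first", "only" and "open" are said of these compounds alone.

The set holds three measured compounds. Compound 1 `Nc1ncnc2c1ncn2[C@@H]1C[C@H](COP(=O)(O)O)[C@H](OP(=O)(O)O)C1` gives 2530 nM in a functional assay for inhibition of P2Y purinoceptor 1 (Meleagris gallopavo); on this read-out lower numbers stand for stronger inhibition and higher numbers for weaker inhibition. Compound 2 `CNc1ncnc2c1ncn2C1CC(OP(=O)(O)O)C2(COP(=O)(O)O)CC12` gives 157 nM in this assay, the lowest number of the three. Compound 3 `CNc1ncnc2c1ncn2C1COC(COP(=O)(O)O)C(OP(=O)(O)O)C1` gives 1640 nM in this assay, the second highest of the three numbers; its gap to compound 1 lies within the usual scatter, while compound 2 sits well below it, a gap beyond the scatter.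

Compound 4 `CNc1nc(Cl)nc2c1ncn2C1COC(COP(=O)(O)O)C(OP(=O)(O)O)C1` has not yet been measured. It differs from compound 3 in one place: chloro in place of hydrogen on an aromatic carbon. For the measured compounds named here, no measured pair in this set shares that change, so the size of its effect in this assay is not known from these data.

The account therefore rests on expectation alone. For compound 4 a moderately lower number is expected, a step from compound 3 to compound 4 of about a 2.3-fold lower number from compound 3 to compound 4 (0.37 log units; beyond the scatter), with wide uncertainty. The estimate for compound 4 in this assay is 700 nM, with a range from 200 nM to 2500 nM.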

Compound 4, half-maximal inhibitory concentration: 566 nM
Beside the measured number, compound 4's estimate is 1.2-fold (0.09 log units) above it; low and high end bracket the measured number.
By their numbers in this assay, from the lowest: compound 2; then compound 4; then compounds 3 and 1 (each within the scatter of the next).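

In this assay, for the compounds shown here, chloro in place of hydrogen on the aromatic carbon between two ring nitrogen atoms gives a 2.9-fold lower number from compound 3 to compound 4 (0.46 log units; beyond the scatter) and so provides the first reading of a change in one place, since no two earlier compounds differed in only one place. The step lies beyond the scatter, which shows that this ring carbon is not indifferent to what it carries: with the rest of compound 3 unchanged, a single chlorine atom moves the number toward stronger inhibition.

From the compounds shown here alone, whether fluoro, bromo, a methoxy group or an amine on this carbon would move the number the same way remains open, as does whether chloro would give a similar step on the core of compound 2. Why the number moves also stays open, as nothing measured here bears on the cause.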